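The source may hold more compounds than are shown below. What is called first, only, known or untested is meant among the compounds shown, and "the series" means these compounds.

Compound 1 `CCCCc1ccc(-c2cc(=O)c3c(o2)C(CC)(CC)C(=O)C(CC)=C3O)cc1`: 111 uM
Compound 2 `CCCOc1ccc(-c2cc(=O)c3c(o2)C(CC)(CC)C(=O)C(CC)=C3O)cc1`: > 50.5 uM (a limit)
Compound 3 `CCC1=C(O)c2c(oc(-c3ccc(SC)cc3)cc2=O)C(CC)(CC)C1=O`: > 52.1 uM (a limit)

In a functional assay on KB cells (Homo sapiens) for antiproliferative activity, read by sulforhodamine B assay, with a stated time of 3 days (on this read-out higher numbers stand for an effect only at larger amounts of compound and lower numbers for an effect already at smaller amounts), compound 1 gives 111 uM. For compound 2 the value > 50.5 uM is a limit of the assay, not a number. For compound 3 the value > 52.1 uM is likewise only a limit (the limit of > 52.1 uM in this assay, at which 1 of the 3 values shown sits); so compound 3 stands at the edge of what this assay could read. Compound 4 `CCC1=C(O)c2c(oc(-c3ccccc3OC)cc2=O)C(CC)(CC)C1=O` differs from compound 3 by 2-methoxyphenyl in place of 4-(methylsulfanyl)phenyl on an aromatic carbon. Among the compounds with values here, the measured steps a step that the limit leaves unreadable from compound 1 to compound 2, a step that the limit leaves unreadable from compound 1 to compound 3 and a step that the two limits leave unreadable from compound 2 to compound 3 are all left unreadable by the limits, so no measured step gives a readable size for this change. I therefore expect compound 4 to stay in the same weak region, a step that the limit leaves unreadable from compound 3 to compound 4, with an estimated value of 70 uM and a range from 20 uM to 250 uM.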

Compound 4, concentration for half-maximal effect: 40.8 uM
The estimate for compound 4 lay 1.7-fold (0.23 log units) above the measured number; the measured number falls inside the stated range.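

In this assay compound 4 gives a readable number, 40.8 uM, so this position, next to the ring oxygen, can carry 2-methoxyphenyl and still give a measurable effect. Compound 3 has only a limit, not a number: the limit of > 52.1 uM in this assay, at which 1 of the 4 values shown sits. Within the data shown here, the change therefore reads only as an at least 1.2-fold lower number from compound 3 to compound 4 (0.10 log units; that floor lies within the scatter), so it may be small or larger, and the earlier steps among compound 1, compound 2 and compound 3 cannot be read either.

Still open, from the compounds shown here alone, is how a phenyl ring carrying an amine or a carboxylic acid would read at this position.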